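Swapping a Chlorophenyl for a Difluorophenyl on the Core

The source may hold more compounds than are shown below. What is called first, only, known or untested is meant among the compounds shown, and "the series" means these compounds.

Of the compounds shown here, two have been measured in an assay on cells for inhibition of histone deacetylase 4 (Homo sapiens), read by fluorescence, with a stated time of 30 min; a lower number here means a stronger inhibitor, a higher number a weaker inhibitor. Compound 1 `O=C1NC(=O)/C(=C\c2ccc(OCC(=O)N3N=C(c4ccccc4)CC3c3ccccc3Cl)cc2)S1` gives 1200 nM. Compound 2 `O=C1NC(=O)/C(=C\c2ccc(OCC(=O)N3N=C(c4ccc(F)cc4)CC3c3ccccc3Cl)cc2)S1` gives 1100 nM. Going by the values given here, the only step measured so far, a 1.1-fold lower number from compound 1 to compound 2 (0.04 log units; within the scatter), introduces a fluoro in place of hydrogen on an aromatic carbon and lands within the scatter. Among these two numbers compound 2 shows the lower one, but its gap to compound 1 is within the scatter, so the two cannot be ranked.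

Compound 3 `O=C1NC(=O)/C(=C\c2ccc(OCC(=O)N3N=C(c4ccc(F)cc4)CC3c3ccc(F)cc3F)cc2)S1` differs from compound 2 by 2,4-difluorophenyl in place of 2-chlorophenyl on a saturated ring carbon, on a saturated ring carbon of the five-membered non-aromatic ring with two nitrogens. Among the compounds with values here, the single measured step, that from compound 1 to compound 2, shows no shift beyond the scatter on a fluorine change, and no measured step speaks to a chlorine-for-fluorine swap on this ring carbon. Compound 3 is therefore expected to stay near compound 2, with an estimated step of no change at the digits printed from compound 2 to compound 3 (within the scatter) in this assay and an estimated value of 1100 nM, between 400 nM and 3000 nM.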

Compound 3, half-maximal inhibitory concentration: 1600 nM
The estimate for compound 3 lay 1.5-fold (0.16 log units) below the measured number; low and high end bracket the measured number.
By their numbers in this assay, from the lowest: compounds 2, 1 and 3 (each within the scatter of the next).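

Placing 2,4-difluorophenyl in place of 2-chlorophenyl on the saturated ring carbon next to the ring nitrogen gives a 1.5-fold higher number from compound 2 to compound 3 (0.16 log units; within the scatter) in this assay, so compound 2 and compound 3 cannot be ranked. The earlier step changed only the group on the ring atom that bears 4-fluorophenyl in compound 2, whereas this step shows that the group on the saturated ring carbon can also be exchanged without a shift beyond the scatter. Nothing measured here offers an explanation for this result.

The two groups compared at this ring carbon are both halogen-bearing phenyl rings, so they say little about very different groups. From the compounds shown here alone, whether a phenyl ring carrying an amine or a carboxylic acid, or a plain phenyl ring, would stay within the scatter remains open.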